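Three purine analogues that sit at the assay ceiling

This account rests on a few compounds, and the source may have more. Where it says the series, first, only, none or still open, it means among the compounds named here.

The study compares two pairs of compounds built on related cores. Compound 1 `CC(O)n1cnc2c(N)nc(I)nc21` carries a 1-hydroxyethyl group on an aromatic nitrogen, and compound 2 `Nc1nc(I)nc2c1ncn2OCCO` carries a 2-hydroxyethoxy group at the same position. In a functional assay (Homo sapiens) for inhibition (on this read-out higher numbers stand for weaker inhibition and lower numbers for stronger inhibition), compound 1 gives only a limit, > 500000 nM. In this assay compound 2 likewise gives only a limit, > 500000 nM. The change between them is 2-hydroxyethoxy in place of 1-hydroxyethyl on an aromatic nitrogen, and the two limits leave its size unreadable: a step that the two limits leave unreadable from compound 1 to compound 2.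

Compound 3 `CC(O)n1cnc2c(S)nc(F)nc21` rests on a core that differs from that of compound 1; that difference is not broken down here. In this assay compound 3 gives only a limit, > 500000 nM. Going by the values given here, all three values so far share the same limit, (the limit of > 500000 nM in this assay, at which 3 of the 3 values shown sit).

Compound 4 `OCCOn1cnc2c(S)nc(F)nc21` is not yet measured. It differs from compound 3 by 2-hydroxyethoxy in place of 1-hydroxyethyl on an aromatic nitrogen, the same change that separates compound 1 from compound 2, since the place described is the same word for word. With compound 3 already at the limit > 500000 nM and compound 2 at the limit > 500000 nM after this change, the step from compound 3 to compound 4 is expected to be small, a step that the limit leaves unreadable from compound 3 to compound 4, and to remain unreadable. Compound 4 is accordingly expected to give about 800000 nM in this assay, somewhere between 300000 nM and 3000000 nM, most likely reported again as a limit.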

Compound 4, half-maximal inhibitory concentration: > 500000 nM
Compound 4: a limit, no number (the forecaster's own chance of this, stated with the estimate: 90%); the middle value lies beyond the limit too.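

Compound 4 also gives only a limit in this assay, so no step can be read from compound 3 to compound 4, just as none could be read from compound 1 to compound 2. All four values coincide: the limit of > 500000 nM in this assay, at which 4 of the 4 values shown sit.

The compounds shown leave open whether 2-hydroxyethoxy in place of 1-hydroxyethyl on an aromatic nitrogen changes inhibition at all, and how strongly, if at all, any of the four inhibits.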